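Benzyl substituent exchange: from compound 1 to compound 4

A few compounds are considered here, and "the series" means these few. Any claim that something is new, unique, unknown or untested is made for them only; others in the source may bear on it.

Compound 1 `Nc1cc(N)c2nc(-c3ccccc3)c(NCc3ccc(Cl)c(Cl)c3)nc2c1` is the reference point of these notes. Among the compounds with values here, in a functional assay on CAKI-1 cells (Homo sapiens) for inhibition, read by sulforhodamine B assay, with a stated time of 48 h (a lower number here means a stronger inhibitor of growth, a higher number a weaker inhibitor of growth), compound 1 gives 13200 nM, the higher of the two numbers available so far. Compound 2 `Nc1cc(N)c2nc(-c3ccccc3)c(Oc3ccc(F)cc3)nc2c1` gives 11200 nM in this assay, a value that sits within the scatter of compound 1, so no order between the two can be claimed. Compound 3 `CCOC(=O)[C@H](CCC(=O)O)NC(=O)c1ccc(CNc2nc3cc(N)cc(N)c3nc2-c2ccccc2)cc1` is reported in this assay only as a limit, < 100000 nM, and not as a number. Within the data shown here, the one piece of evidence beyond the plain numbers is the limit of < 100000 nM in this assay, at which 1 of the 3 values shown sits.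

Compound 4 `Nc1cc(N)c2nc(-c3ccccc3)c(NCc3ccc(F)cc3)nc2c1` has not yet been measured in this assay. It differs from compound 1 in a single place: 4-fluorophenyl in place of 3,4-dichlorophenyl on a saturated chain carbon bound to a nitrogen on an aromatic ring. Among the measured compounds shown here, no measured pair in this set shows the same exchange, so the size of the step has to be judged without a direct precedent. Compound 2 also carries a 4-fluorophenyl and in this assay gives a value indistinguishable from compound 1 within the scatter, which is the only hint available.

The step from compound 1 to compound 4 is therefore expected to be small, a 1.2-fold higher number from compound 1 to compound 4 (0.08 log units; within the scatter), not clearly beyond the scatter in either direction. Compound 4 is estimated at 16000 nM in this assay, with a range from 6000 nM to 45000 nM.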

Compound 4, concentration for 50% growth inhibition: 15100 nM
Compound 4: the middle estimate sits 1.1-fold (0.03 log units) above what was measured, and the stated range covers the measured number.
By their numbers in this assay, from the lowest: compounds 2, 1 and 4 (each within the scatter of the next).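

Replacing 3,4-dichlorophenyl with 4-fluorophenyl on a saturated chain carbon bound to a nitrogen on an aromatic ring now has a direct reading in this assay and gives a 1.1-fold higher number from compound 1 to compound 4 (0.06 log units; within the scatter), so the two benzyl groups are not separated at this position. With the 4-fluorophenyl retained, (4-fluorobenzyl)amino in place of 4-fluorophenoxy on an aromatic carbon gives a 1.3-fold higher number from compound 2 to compound 4 (0.13 log units; within the scatter), which adds a second exchange at this part of the molecule that also stays inside the scatter. Compound 1, compound 2 and compound 4 therefore form one group without an order, and neither the substituents on the benzyl ring nor the exchange of the benzylamino and phenoxy groups separates them here.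

Still open, on these data alone, is whether a nitrile or a trifluoromethyl on the benzyl ring, or a longer chain in place of the single saturated carbon, would give a number clearly apart from this group. Nothing shown here bears on what lies behind these small steps.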